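Amidine to imidazoline swap in two cytotoxicity cores

This account rests on a few compounds, and the source may have more. Where it says the series, first, only, none or still open, it means among the compounds named here.

Compound 1 `CC(C)NC(=N)c1ccc2cc(-c3cccc(OCCCCOc4ccccc4)c3)oc2c1` and compound 2 `c1ccc(OCCCCOc2cccc(-c3cc4ccc(C5=NCCN5)cc4o3)c2)cc1` share one core; compound 3 `CC(C)NC(=N)c1ccc2cc(-c3ccc(OCCCCCCOc4ccccc4)cc3)oc2c1` and compound 4 `c1ccc(OCCCCCCOc2ccc(-c3cc4ccc(C5=NCCN5)cc4o3)cc2)cc1` share another. The difference between the two cores is not broken down here. In an ADME assay on L6 cells (Rattus norvegicus) for cytotoxicity, read by resazurin assay, with a stated time of 70 h (a lower number here means a stronger inhibitor, a higher number a weaker inhibitor), compound 1 gives 46500 nM, compound 2 gives 5800 nM, and compound 3 gives 4900 nM. The change from compound 1 to compound 2 is a group of 5 heavy atoms (3 carbon, 2 nitrogen; one five-membered non-aromatic ring with 2 hetero atoms) in place of a group of 6 heavy atoms (4 carbon, 2 nitrogen; no ring), on an aromatic carbon, and it made an 8.0-fold lower number from compound 1 to compound 2 (0.90 log units; beyond the scatter). The same change is made from compound 3 to compound 4: a group of 5 heavy atoms (3 carbon, 2 nitrogen; one five-membered non-aromatic ring with 2 hetero atoms) in place of a group of 6 heavy atoms (4 carbon, 2 nitrogen; no ring), on an aromatic carbon. Compound 3 and compound 2 lie within the scatter of each other in this assay, so no order between them is read. Compound 4 is not yet measured in this assay. Within the data shown here, the expectation for compound 4 rests on the single earlier pair carried over to the second core: an expected 3.3-fold lower number from compound 3 to compound 4 (0.51 log units; beyond the scatter), taken as smaller than an 8.0-fold lower number from compound 1 to compound 2 (0.90 log units; beyond the scatter) since only one pair supports the direction and the cores are not matched. Compound 4 is estimated at 1500 nM in this assay, with a range from 500 nM to 5000 nM.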

Compound 4, half-maximal inhibitory concentration: 3400 nM
Beside the measured number, compound 4's estimate is 2.3-fold (0.36 log units) below it, and the stated range covers the measured number.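

In this assay, the amidine to imidazoline swap gives a 1.4-fold lower number from compound 3 to compound 4 (0.16 log units; within the scatter), so no shift can be read from this change on the core of compound 3. Two pairs set no rule for the series: they do not show which difference between the two cores goes with the gap, nor how the step would fall on a third core. The change therefore does not carry over in size from the core of compound 1 to the core of compound 3, and the two steps differ: the same change on two cores in this assay, an 8.0-fold lower number (0.90 log units; beyond the scatter) from compound 1 to compound 2 and a 1.4-fold lower number (0.16 log units; within the scatter) from compound 3 to compound 4, 5.6-fold (0.75 log units) apart, beyond the scatter of two such steps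

The compounds shown leave open how other groups on the same aromatic carbon, such as a primary amine or a carboxylic acid, would read in this assay on either core. Also open, from the compounds shown here alone, is whether a longer chain on either core would bring the step closer to the one seen on the core of compound 1 or the one seen on the core of compound 3.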